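From 2-methoxyphenyl to 3-methylphenyl: an expected gain

The compounds below may be only part of what the source reports. "The series", "measured", "known", "first", "only" and "open" are said of these compounds alone.

Within the data shown here, compound 1 `COc1ccccc1NC(=S)N/N=C/c1ccc2ccccc2n1` holds the higher, weaker number of the two compounds measured so far in a functional assay on HL-60 cells (Homo sapiens) for antiproliferative activity, read by sulforhodamine B assay, with a stated time of 72 h; a higher number here means a weaker inhibitor, a lower number a stronger inhibitor: compound 1 gives 91700 nM, and compound 2 `FC(F)(F)c1ccccc1NC(=S)N/N=C/c1ccc2ccccc2n1` gives 13200 nM. Compound 3 `Cc1cccc(NC(=S)N/N=C/c2ccc3ccccc3n2)c1` awaits measurement. It keeps the core of compound 1 and swaps one group, with 3-methylphenyl in place of 2-methoxyphenyl on an amide-type nitrogen. Among the measured compounds shown here, only one measured step bears on this, and only loosely. Trifluoromethyl in place of methoxy gave a modest change, a 6.9-fold lower number from compound 1 to compound 2 (0.84 log units; beyond the scatter). Compound 3 also loses the methoxy, but a different group enters, so that step is only a rough guide. A change in the same direction, somewhat smaller, is therefore expected in this assay, an estimated 3.3-fold lower number from compound 1 to compound 3 (0.52 log units; beyond the scatter). The expected value for compound 3 is 28000 nM, within an estimated range of 9000 nM to 85000 nM.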

Compound 3, half-maximal inhibitory concentration: > 100000 nM
Compound 3: a limit, no number (the forecaster's own chance of this, stated with the estimate: 10%); middle value at least 3.5-fold (0.55 log units) from the limit.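

Compound 3 gives a limit of the assay, not a number: the limit of > 100000 nM in this assay, at which 1 of the 3 values shown sits.

The step reads an at least 1.0-fold higher number from compound 1 to compound 3 (0.03 log units; that floor lies within the scatter), so only its floor is known, and in this assay 3-methylphenyl on this amide-type nitrogen does not give a lower number than 2-methoxyphenyl. Losing the methoxy is therefore not enough on its own to reproduce the step seen with trifluoromethyl, a 6.9-fold lower number from compound 1 to compound 2 (0.84 log units; beyond the scatter), which shows that the group entering here matters and not only the group leaving.

As far as these compounds go, how far compound 3 lies beyond the limit remains unknown, so the true size of this step stays open. Also open, from the compounds shown here alone, is what an amine or a carboxylic acid would give in place of the methyl on this phenyl ring.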